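Swapping a fluoro for a methoxy in a weakly active pair

The compounds below may be only part of what the source reports. "The series", "measured", "known", "first", "only" and "open" are said of these compounds alone.

Measured so far:
- compound 1, `C=C(c1ccc(F)c(F)c1)C1COC2(CCCCC2)OO1`: 61200 nM
- compound 2, `C=C(c1ccc(Cl)c(Cl)c1)C1COC2(CCCCC2)OO1`: 39400 nM

Two compounds share a core and differ only in the groups on the aromatic ring. In a functional assay on BEAS-2B cells (Homo sapiens) for inhibition, read by MTT assay, with a stated time of 72 h (on this read-out lower numbers stand for stronger inhibition and higher numbers for weaker inhibition), compound 1 gives 61200 nM, which is the highest of the two numbers seen. In this assay compound 2 gives 39400 nM. The gap between compound 1 and compound 2 lies within the usual scatter of this kind of measurement, so nothing can be said about which of the two inhibits more strongly; both are weak inhibitors.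

The next compound, compound 3, `C=C(c1ccc(OC)c(F)c1)C1COC2(CCCCC2)OO1`, has not yet been measured. It is made from compound 1 by one change: methoxy in place of fluoro on an aromatic carbon. Within the data shown here, no measured pair shows what such a change does here, so the expectation rests only on the weak numbers of compound 1 and compound 2. The step is expected to be small, in either direction, and not clearly beyond the scatter, so compound 3 is estimated at 50000 nM with a range of 20000 nM to 150000 nM. This estimate for compound 3 implies a step of a 1.2-fold lower number from compound 1 to compound 3 (0.09 log units; within the scatter).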

Compound 3, half-maximal inhibitory concentration: 37700 nM
For compound 3 the middle estimate is 1.3-fold (0.12 log units) above the measured one; the measured number falls inside the stated range.
By their numbers in this assay, from the lowest: compounds 3, 2 and 1 (each within the scatter of the next).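

In this assay, putting a methoxy in place of the fluoro gives a 1.6-fold lower number from compound 1 to compound 3 (0.21 log units; within the scatter). Among these compounds, this is the first pair that isolates a single change at one place on the aromatic ring: a carbon that is ortho to a fluoro group and para to a large group. Here a group with 2 heavy atoms and 1 hydrogen-bond acceptor replaces a single fluorine, yet the two compounds cannot be told apart, and no other information on the compounds helps to interpret this result.

This one pair cannot show whether other groups at this position, such as an amine, a carboxylic acid or a longer chain like butoxy, would move the number beyond the usual scatter, in either direction. It also leaves open whether methoxy in place of a halogen would give a similar result on the dichloro-substituted ring of compound 2, or at the other substituted carbon of the ring in compound 1.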